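A few compounds are considered here, and "the series" means these few. Any claim that something is new, unique, unknown or untested is made for them only; others in the source may bear on it.

Measured in an ADME assay on Vero cells (Chlorocebus sabaeus) for cytotoxicity, read by MTT assay, with a stated time of 96 h; on this read-out higher numbers stand for lower toxicity in this test and lower numbers for higher toxicity in this test:
- compound 1 `COc1cc(NCc2ccc(C)s2)ccc1-c1cnco1`: 24700 nM
- compound 2 `COc1cc(NCc2ccc(Cl)s2)ccc1-c1cnco1`: 53800 nM
- compound 3 `COc1cc(NCc2ccc(Br)s2)ccc1-c1cnco1`: 47300 nM

These three compounds share a core and differ in a single group. Compound 3 lies within the usual scatter of both others, as a 1.1-fold lower number from compound 2 to compound 3 (0.06 log units; within the scatter) and a 1.9-fold higher number from compound 1 to compound 3 (0.28 log units; within the scatter) show. Among the compounds with values here, only one step clears the scatter, and modestly: a 2.2-fold higher number from compound 1 to compound 2 (0.34 log units; beyond the scatter).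

The unmeasured compound 4 `CCc1ccc(CNc2ccc(-c3cnco3)c(OC)c2)s1` carries ethyl in place of bromo on an aromatic carbon. Within the data shown here, no measured compound holds ethyl, so any forecast rests on a near neighbour. The closest comparison is compound 1, which holds methyl at this place. Its swap to bromo gave a 1.9-fold higher number from compound 1 to compound 3 (0.28 log units; within the scatter), and the change to compound 4 runs the opposite way, from bromo back to a carbon group. That points to a somewhat lower number, though the evidence is weak, since this one step did not clear the scatter.

The expected step is small, probably within the scatter: a 1.6-fold lower number from compound 3 to compound 4 (0.20 log units; within the scatter).

Compound 4 is estimated at about 30000 nM, with an expected range of 15000 nM to 55000 nM.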

Compound 4, half-maximal cytotoxic concentration: 13600 nM
Compound 4: middle estimate off by 2.2-fold (0.34 log units), on the high side; the whole stated range lies above it.
By their numbers in this assay, from the lowest: compounds 4, 1, 3 and 2 (each within the scatter of the next, the first and the last beyond it).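

In this assay, ethyl at this place on the five-membered aromatic ring with 1 sulfur gives the first clear separation of a halogen-bearing compound from a carbon-bearing one on both the bromo side (a 3.5-fold lower number from compound 3 to compound 4 (0.54 log units; beyond the scatter)) and the chloro side (a 4.0-fold lower number from compound 2 to compound 4 (0.60 log units; beyond the scatter)). Lower numbers here stand for higher toxicity in this test, and ethyl reads as the less favourable group in both comparisons. Going from methyl to ethyl, one step further out along the carbon group, adds nothing that can be read (a 1.8-fold lower number from compound 1 to compound 4 (0.26 log units; within the scatter)), so the two carbon groups cannot be told apart in this test. The split into carbon groups and halogens is not clean, though, as compound 1 still lies within the scatter of compound 3 and only compound 4 is clearly apart from both halogen compounds.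

Going by these compounds, whether a longer chain such as propyl, a methoxy group, a nitrile or an amine at this place would fall with the carbon groups or with the halogens stays open. Nothing in hand explains why ethyl stands apart from chloro and bromo in this test.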